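Adding a nitro group to compound 2: what to expect

This account rests on a few compounds, and the source may have more. Where it says the series, first, only, none or still open, it means among the compounds named here.

Measured so far:
- compound 1, `O=c1[nH]c(=O)n(COCCO)cc1[N+](=O)[O-]`: > 400 ug/mL
- compound 2, `Nc1ccn(COCCO)c(=O)n1`: > 400 ug/mL

Both measured compounds were tested in a functional assay (Oryctolagus cuniculus) for inhibition; a lower number here means a stronger inhibitor, a higher number a weaker inhibitor. Compound 1 gives > 400 ug/mL in this assay, which is a limit of the assay and not a number. Compound 2 gives > 400 ug/mL in this assay, again a limit rather than a number. So compound 2 stands at the edge of what this assay can report, together with compound 1 (the limit of > 400 ug/mL in this assay, at which 2 of the 2 values shown sit). For the measured compounds named here, no step between two measured compounds is available, so no measured change in inhibition can be described.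

The unmeasured compound is compound 3, `Nc1nc(=O)n(COCCO)cc1[N+](=O)[O-]`. It differs from compound 2 in one place: nitro in place of hydrogen on an aromatic carbon. The new group sits ortho to an amino group and two atoms from the ring nitrogen of the shared core.

Because compound 2 sits at the limit > 400 ug/mL, and compound 1, which also carries a nitro group, sits at the same limit > 400 ug/mL, no movement beyond the scatter is expected for a number no higher from compound 2 to compound 3 (the limit leaves the size open). Compound 3 is therefore estimated at 400 ug/mL in this assay, within 150 ug/mL to 1500 ug/mL, most likely reported again only as a limit.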

Compound 3, concentration for 50% inhibition: > 400 ug/mL
Compound 3: no number, only a limit; the forecaster's own chance of this, stated with the estimate: 80%; the middle value lies on the limit itself.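

Compound 3 gives > 400 ug/mL in this assay, which is a limit of the assay and not a number. Compound 2 also has only a limit there, so no step can be read between compound 2 and compound 3. All the compounds shown end at the same point: the limit of > 400 ug/mL in this assay, at which 3 of the 3 values shown sit. On these data alone, how strongly any of them inhibits, and whether swapping hydrogen for nitro changes that, stays open.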